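Pyridyl variants on the shared oxadiazole series: compound 4

This account rests on a few compounds, and the source may have more. Where it says the series, first, only, none or still open, it means among the compounds named here.

Compound 3 `C[C@H](NC(=O)c1cc(C(F)(F)F)nn1C)c1nc(-c2ccnc(N(C)C)c2)no1` stands second highest of the three numbers measured in an assay on T-REx-293 cells for inhibition of potassium channel subfamily T member 1 (Homo sapiens), read by patch clamp; a lower number here means a stronger inhibitor, a higher number a weaker inhibitor: compound 3 gives 454 nM. Its nearest is compound 1 `C[C@H](NC(=O)c1cc(C(F)(F)F)nn1C)c1nc(-c2cccc(F)c2)no1`, which in this assay gives 136 nM; its furthest is compound 2 `C[C@H](NC(=O)c1cc(C(F)(F)F)nn1C)c1nc(-c2ccncc2)no1`, which in this assay gives 5250 nM. The two steps into compound 3 are a 3.3-fold higher number from compound 1 to compound 3 (0.52 log units; beyond the scatter) and a 12-fold lower number from compound 2 to compound 3 (1.06 log units; beyond the scatter); between the other pair the step is a 39-fold higher number from compound 1 to compound 2 (1.59 log units; beyond the scatter).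

Compound 4 `COc1cc(-c2noc([C@H](C)NC(=O)c3cc(C(F)(F)F)nn3C)n2)cc(C)n1` differs from compound 3 in one place: 2-methoxy-6-methylpyridin-4-yl in place of 2-(dimethylamino)pyridin-4-yl on an aromatic carbon. The step that bears most directly on this change is a 12-fold lower number from compound 2 to compound 3 (1.06 log units; beyond the scatter), which shows that what sits on the six-membered aromatic ring moves the number a great deal. Compound 4 keeps a group there, methoxy in place of dimethylamino, and carries a methyl in addition; neither group appears in the measured set, so the step is uncertain. The expectation is a step of about a 1.3-fold lower number from compound 3 to compound 4 (0.11 log units; within the scatter), close to the scatter, with a modest loss somewhat more likely than a gain. Compound 4 is therefore estimated at 350 nM, with a range from 100 nM to 1200 nM.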

Compound 4, half-maximal inhibitory concentration: 505 nM
Compound 4: the middle estimate sits 1.4-fold (0.16 log units) below what was measured; the measured number falls inside the stated range.
By their numbers in this assay, from the lowest: compound 1; then compounds 3 and 4 (each within the scatter of the next); then compound 2.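

Replacing 2-(dimethylamino)pyridin-4-yl with 2-methoxy-6-methylpyridin-4-yl in this assay gives a 1.1-fold higher number from compound 3 to compound 4 (0.05 log units; within the scatter) and so leaves the number unchanged within the scatter, which shows that this position tolerates this exchange of substituents on the pyridine. The recovery from the unsubstituted pyridin-4-yl is therefore not confined to dimethylamino: the new group gives a 10-fold lower number from compound 2 to compound 4 (1.02 log units; beyond the scatter) and still falls short of 3-fluorophenyl, with a 3.7-fold higher number from compound 1 to compound 4 (0.57 log units; beyond the scatter) as the remaining difference. No available measurement accounts for the matching numbers of these two substituted pyridines.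

The separate contributions of methoxy and methyl remain unresolved, as both enter together in compound 4 and neither appears alone on the pyridin-4-yl group. Also open, as far as these compounds go, is whether a morpholine, a nitrile or a chlorine on that group, or a fluorine on the pyridine in the manner of the 3-fluorophenyl of compound 1, would bring the number closer to that of compound 1 in this assay or leave it where compound 3 and compound 4 stand.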